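The compounds below may be only part of what the source reports. "The series", "measured", "known", "first", "only" and "open" are said of these compounds alone.

Of the compounds shown here, three built on one shared core have been measured in a functional assay on A549 cells (Homo sapiens) for antiproliferative activity, read by MTT assay; a lower number here means a stronger inhibitor, a higher number a weaker inhibitor. Compound 1 `COc1ccc2nc(N(Cc3cc(-c4ccc(OC(F)(F)F)cc4)no3)c3nc4ccc(F)cc4s3)sc2c1` gives 37100 nM. Compound 2 `COc1ccc(-c2cc(CN(c3nc4ccc(F)cc4s3)c3nc4ccc(OC)cc4s3)on2)cc1`, tested in this assay, gives 38800 nM. Compound 3 `COc1ccc2nc(N(Cc3cc(-c4cc(OC)c(OC)c(OC)c4)no3)c3nc4ccc(F)cc4s3)sc2c1`, tested in this assay, gives 61900 nM, the highest of the three numbers as they stand, although its distance to compound 2 and to compound 1 both fall within the scatter of the assay. The steps leading to compound 3 are a 1.7-fold higher number from compound 1 to compound 3 (0.22 log units; within the scatter) and a 1.6-fold higher number from compound 2 to compound 3 (0.20 log units; within the scatter); the remaining step, a 1.0-fold higher number from compound 1 to compound 2 (0.02 log units; within the scatter), also stays within the scatter.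

Compound 4 `COc1ccc2nc(N(Cc3cc(-c4ccc(Br)cc4)no3)c3nc4ccc(F)cc4s3)sc2c1` has not yet been measured in this assay. Its difference from compound 3 is 4-bromophenyl in place of 3,4,5-trimethoxyphenyl on an aromatic carbon. The two measured steps that bear on this position, each exchanging the group on the same aromatic carbon, moved the number only within the scatter, so no step beyond the scatter is expected here either; if anything, a slightly lower number, in the direction of compound 1 and compound 2, seems the more likely outcome. Compound 4 is therefore expected to give 40000 nM in this assay, within a range from 18000 nM to 90000 nM. The step thus expected is a 1.5-fold lower number from compound 3 to compound 4 (0.19 log units; within the scatter).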

Compound 4, half-maximal inhibitory concentration: 32700 nM
Compound 4: middle estimate off by 1.2-fold (0.09 log units), on the high side; the measured number falls inside the stated range.
By their numbers in this assay, from the lowest: compounds 4, 1, 2 and 3 (each within the scatter of the next).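

Compound 4 extends the series at the aromatic carbon of the five-membered ring to a halogen-bearing phenyl group, and in this assay the exchange with the largest structural difference so far, which drops all the hydrogen-bond acceptors counted on the leaving group and leaves a smaller group in its place, gives a 1.9-fold lower number from compound 3 to compound 4 (0.28 log units; within the scatter) and so stays inside the usual variation of the measurement. The two narrower exchanges on the same phenyl ring, a 1.2-fold lower number from compound 2 to compound 4 (0.07 log units; within the scatter) and a 1.1-fold lower number from compound 1 to compound 4 (0.05 log units; within the scatter), show that bromo, methoxy and trifluoromethoxy cannot be told apart here, so among these four compounds no exchange at this position moves the number beyond the scatter. Nothing measured here offers an explanation for this flat response.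

The compounds shown all keep a substituted phenyl group on this carbon, so it remains open whether an amine or a carboxylic acid on that phenyl ring, or a cyclohexyl ring in place of it, would move the number beyond the scatter. All four also share the same core, which leaves open what a change there, such as a hydroxyl in place of the methoxy, would do.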